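The compounds below may be only part of what the source reports. "The series", "measured", "known", "first", "only" and "open" are said of these compounds alone.

Compound 1, `COc1ccccc1NC(=O)COc1cc(C)nc2ccc(C(F)(F)F)cc12`. In an ADME assay on HepG2 cells (Homo sapiens) for cytotoxicity, read by trypan blue exclusion, with a stated time of 48 h, in the presence of a further agent that is not named here (a lower number here means that less compound is tolerated, a higher number that more compound is tolerated), compound 1 gives > 128000 nM, which is a limit of the assay.
Compound 2, `COc1cccc(NC(=O)COc2cc(C)nc3ccc(OC)cc23)c1`. In this assay compound 2 gives 24700 nM.
Compound 3, `COc1ccc2nc(C)cc(OCC(=O)Nc3ccccc3Cl)c2c1`. In this assay compound 3 gives > 140000 nM, which is a limit of the assay.

Where compound 1 stands can be said only in part, since its value is a limit rather than a number (the limit of > 128000 nM in this assay, at which 1 of the 3 values shown sits). Compound 3 likewise sits at a limit (the limit of > 140000 nM in this assay, at which 1 of the 3 values shown sits). Among the measured compounds shown here, compound 2 gives the one full number among the three. For the measured compounds named here, the only step between measured compounds that differ in one place is an at least 5.6-fold higher number from compound 2 to compound 3 (0.75 log units; beyond the scatter), a change on the amide-type nitrogen. Compound 4, `COc1ccccc1NC(=O)COc1cc(C)nc2ccccc12`, has not been measured; it differs from compound 1 by hydrogen in place of trifluoromethyl on an aromatic carbon. Going by the values given here, no measured step touches this position, so the step from compound 2 to compound 3 offers no direct guidance, and compound 1 itself provides only a limit. Compound 4 is therefore expected to show no step beyond the scatter, a step that the limit leaves unreadable from compound 1 to compound 4. The estimate for compound 4 in this assay is 150000 nM, between 40000 nM and 500000 nM, with a fair chance that only a limit is reported again.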

Compound 4, half-maximal cytotoxic concentration: 8640 nM
Compound 4: middle estimate off by 17-fold (1.24 log units), on the high side; the whole stated range lies above it.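

The carbon that carries trifluoromethyl in compound 1 lay outside the earlier step on the amide-type nitrogen, and this change now shows that it counts in this assay: hydrogen in place of trifluoromethyl gives an at least 14-fold lower number from compound 1 to compound 4 (1.17 log units; beyond the scatter). The number therefore moves with a change on the shared core as well as with one on the amide-type nitrogen, although these two steps start from different compounds and show no common pattern. The true size of the new step stays unknown, as compound 1 sits at a limit of the assay: the limit of > 128000 nM in this assay, at which 1 of the 4 values shown sits.

The compounds shown leave open whether a nitrile or an amine on this aromatic carbon would behave more like trifluoromethyl or like hydrogen in this assay. They also leave open whether the same step would appear with 2-chlorophenyl on the amide-type nitrogen.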